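Hydroxy on an amine nitrogen of compound 1

The compounds below may be only part of what the source reports. "The series", "measured", "known", "first", "only" and "open" are said of these compounds alone.

Measured compounds:
compound 1 `N=C(N)N/N=C/c1cccc(C(=N)N)n1` gives 10100 nM
compound 2 `N=C(NO)N/N=C/c1cccc(C(=N)N)n1` gives 32900 nM

Going by the values given here, in a functional assay on T-24 cells (Homo sapiens) for antiproliferative activity (on this read-out lower numbers stand for stronger inhibition and higher numbers for weaker inhibition), compound 1 gives 10100 nM and stands lowest of the two numbers so far. Compound 3 `N=C(N)N/N=C/c1cccc(C(=N)NO)n1` is still unmeasured. It differs from compound 1 by hydroxy in place of hydrogen on an amine nitrogen and so carries hydroxy in place of hydrogen on an amine nitrogen. The measured step of a 3.3-fold higher number from compound 1 to compound 2 (0.51 log units; beyond the scatter) is the same kind of replacement on another amine nitrogen and bears on this; it is modest but beyond the scatter. A step of similar size towards a higher number is therefore expected, here a 2.8-fold higher number from compound 1 to compound 3 (0.44 log units; beyond the scatter) as an estimate. For compound 3 the estimated value is 28000 nM with 11000 nM to 70000 nM as the expected range.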

Compound 3, half-maximal inhibitory concentration: > 119000 nM
Compound 3 was reported as a limit; the forecaster's own chance of this, stated with the estimate: 10%; middle value at least 4.2-fold (0.62 log units) away from the limit.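

In this assay, hydroxy in place of hydrogen on an amine nitrogen whose other neighbours are carbon with a double bond to nitrogen gives a large step (an at least 11-fold higher number from compound 1 to compound 3 (1.07 log units; beyond the scatter)), while the same kind of replacement on another amine nitrogen gives only a modest one (a 3.3-fold higher number from compound 1 to compound 2 (0.51 log units; beyond the scatter)). The outcome of this change therefore depends on which amine nitrogen carries it. The value of compound 3 is a limit: the limit of > 119000 nM in this assay, at which 1 of the 3 values shown sits.

The compounds shown leave open how far compound 3 truly lies from compound 1. They also leave open whether methoxy or methyl on this amine nitrogen would behave as hydroxy does.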